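The compounds below may be only part of what the source reports. "The series", "measured", "known", "first", "only" and "open" are said of these compounds alone.

Measured compounds:
compound 1 `COc1ccc(-c2nc3ccccc3s2)cc1NC(=O)c1cc([N+](=O)[O-])ccc1Cl` — > 25000 nM
compound 2 `O=C(Nc1cccc(-c2nc3ccccc3s2)c1)c1cc([N+](=O)[O-])ccc1Cl` — > 27000 nM
compound 3 `O=C(Nc1cc(-c2nc3ccccc3s2)ccc1F)c1cc([N+](=O)[O-])ccc1Cl` — > 25000 nM

In an ADME assay on HepG2 cells (Homo sapiens) for cytotoxicity, with a stated time of 72 h (on this read-out higher numbers stand for an effect only at larger amounts of compound and lower numbers for an effect already at smaller amounts), compound 1 gives > 25000 nM, which is a limit of the assay rather than a number. Compound 2 likewise gives only a limit, > 27000 nM. Compound 3 also stops at a limit, > 25000 nM. Compound 2 therefore stands nowhere definite on the numbers shown: every value in the set is a limit, two of them at the limit of > 25000 nM in this assay, at which 2 of the 3 values shown sit, and one at the limit of > 27000 nM in this assay, at which 1 of the 3 values shown sits. The three steps among them, a step that the two limits leave unreadable from compound 1 to compound 2, a step that the two limits leave unreadable from compound 1 to compound 3 and a step that the two limits leave unreadable from compound 2 to compound 3, cannot be read for size.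

Compound 4 `O=C(Nc1cccc(-c2ccccc2)c1)c1cc([N+](=O)[O-])ccc1Cl` is reached from compound 2 by phenyl in place of 1,3-benzothiazol-2-yl on an aromatic carbon. Going by the values given here, none of the measured steps touches this group, and none gives a readable size, so no step in this assay can be predicted with any direction beyond the scatter. Compound 4 is expected to behave like compound 2, with an estimated step that the limit leaves unreadable from compound 2 to compound 4, and its estimated value is 30000 nM, between 10000 nM and 100000 nM.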

Compound 4, half-maximal effective concentration: > 27000 nM
Compound 4: no number, only a limit; the forecaster's own chance of this, stated with the estimate: 75%; the middle value is on the limit's open side.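

Compound 2 and compound 4 each give only a limit, not a number, so no new step can be read between them. The compounds shown leave open at what concentration, if any, each one harms the cells, and whether phenyl in place of 1,3-benzothiazol-2-yl changes that concentration.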